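A few compounds are considered here, and "the series" means these few. Any claim that something is new, unique, unknown or untested is made for them only; others in the source may bear on it.

In a functional assay on P388 cells (Mus musculus) (on this read-out lower numbers stand for stronger inhibition and higher numbers for weaker inhibition), compound 1 `O=C(/C=C/c1ccc(Br)cc1)Oc1ccc(/C=C2\CCCCC2=O)cc1` gives > 50000 nM, which is a limit and not a number. Compound 2 `CN(C)CC1CCC/C(=C\c2ccc(OC(=O)/C=C/c3ccc(F)cc3)cc2)C1=O` gives 4550 nM, and compound 3 `CN(C)CC1CCC/C(=C\c2ccc(OC(=O)/C=C/c3ccc(Br)cc3)cc2)C1=O` gives 4030 nM. These two numbers stand together: with bromo in place of fluoro on an aromatic carbon, the result is a 1.1-fold lower number from compound 2 to compound 3 (0.05 log units; within the scatter). Compound 1 and compound 3 are much further apart. With (dimethylamino)methyl in place of hydrogen on a saturated ring carbon, the step is an at least 12-fold lower number from compound 1 to compound 3 (1.09 log units; beyond the scatter).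

Compound 4 `COc1ccc(C(=O)Oc2ccc(/C=C3\CCCC(CN(C)C)C3=O)cc2)cc1` keeps that (dimethylamino)methyl group and differs from compound 3 elsewhere: 4-methoxyphenyl in place of 2-(4-bromophenyl)ethenyl on a carbonyl carbon. In words, 4-methoxyphenyl stands in place of 2-(4-bromophenyl)ethenyl on a carbonyl carbon. The large step from (dimethylamino)methyl therefore does not apply here. The halogen step is the only measured one that touches the departing group, and it stayed within the scatter. Among the compounds with values here, no measured compound shows what happens when the whole group is exchanged, so the expectation is loose, and no clear move in either direction is expected in this assay. The expected change is a 1.2-fold higher number from compound 3 to compound 4 (0.09 log units; within the scatter). For compound 4 the estimated value is 5000 nM, with an expected range from 1500 nM to 20000 nM.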

Compound 4, half-maximal inhibitory concentration: 332 nM
Estimate against measurement, compound 4: 15-fold (1.18 log units) above; measured number below the stated range.
By their numbers in this assay, from the lowest: compound 4; then compounds 3 and 2 (each within the scatter of the next). At a limit, above all of these: compound 1.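

Within the data shown here, until now, the only change to the group on this carbonyl carbon was the halogen swap, which stayed within the scatter, so this place could have seemed indifferent to what it carries. Exchanging the whole group for 4-methoxyphenyl shows otherwise: in this assay there is a 12-fold lower number from compound 3 to compound 4 (1.08 log units; beyond the scatter) and also a 14-fold lower number from compound 2 to compound 4 (1.14 log units; beyond the scatter) with the fluoro partner as the starting point. The two steps agree, so the drop does not hang on which halogen leaves, and the group on the carbonyl carbon now stands beside the (dimethylamino)methyl group as a place where the number can move strongly.

Going by these compounds, the exchange alters two things at once, as the double bond outside the aromatic ring goes and a methoxy oxygen arrives, and how 4-bromophenyl or 2-(4-methoxyphenyl)ethenyl would behave on the same carbonyl carbon stays open. Nothing given here explains the size of this step.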